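Swapping methylamino for methylpiperazinyl on the shared core

A few compounds are considered here, and "the series" means these few. Any claim that something is new, unique, unknown or untested is made for them only; others in the source may bear on it.

Compound 1 `CNc1nc(NCc2ccc(C(=O)Nc3ccc(F)cc3)cc2)c2ccccc2n1` gives 4100 nM in a functional assay on SW480 cells (Homo sapiens) for inhibition, read by luminescence and resazurin assay, with a stated time of 3 days (on this read-out lower numbers stand for stronger inhibition and higher numbers for weaker inhibition), the highest of the three numbers measured. Compound 2 `CNc1nc(NCc2ccc(NC(=O)c3ccc(F)cc3)cc2)c2ccccc2n1` gives 2000 nM, and compound 3 `CCCNc1nc(NCc2ccc(C(=O)Nc3ccc(Cl)nc3)cc2)c2cc(C)ccc2n1` gives 2100 nM. Among the compounds with values here, the only single-site step known, a 2.1-fold lower number from compound 1 to compound 2 (0.31 log units; beyond the scatter), concerns the amide linkage and not the place changed here. Compound 4 `CC1CN(c2nc(NCc3ccc(C(=O)Nc4ccc(F)cc4)cc3)c3ccccc3n2)CCN1` differs from compound 1 by 3-methylpiperazin-1-yl in place of methylamino on an aromatic carbon. No measured pair changes this position; nothing among these compounds shows how this assay responds to it, and no step beyond the scatter is expected in either direction. Compound 4 is therefore estimated at 3200 nM, within 800 nM to 13000 nM, which would mean a 1.3-fold lower number from compound 1 to compound 4 (0.11 log units; within the scatter) as the expected step.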

Compound 4, half-maximal inhibitory concentration: 3200 nM
For compound 4 middle estimate and measured number coincide at the digits printed; the measured number falls inside the stated range.
By their numbers in this assay, from the lowest: compounds 2, 3, 4 and 1 (each within the scatter of the next, the first and the last beyond it).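

In this assay the change at this place gives a 1.3-fold lower number from compound 1 to compound 4 (0.11 log units; within the scatter) and so stays within the scatter. The earlier compounds shown here held no change at this position, and here a six-membered non-aromatic ring on the aromatic carbon takes the place of methylamino with no clear shift in the number. No measurement shown gives a reason for this. Going by these compounds, whether a morpholine ring, a longer chain or a carboxylic acid at this place would also leave the number unmoved remains open, as does whether 3-methylpiperazin-1-yl would do the same on compound 2.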